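A few compounds are considered here, and "the series" means these few. Any claim that something is new, unique, unknown or untested is made for them only; others in the source may bear on it.

In a physicochemical assay for pharmacokinetics (a lower number here means that the compound disappears faster, a higher number that the compound lasts longer), three compounds have been measured so far. They are compound 1 (`O=C(NCc1ccccc1Br)N1C(=O)c2ccccc2S1(=O)=O`), compound 2 (`O=C(NCc1ccccc1F)N1C(=O)c2ccccc2S1(=O)=O`) and compound 3 (`O=C(c1ccccc1)N1C(=O)c2ccccc2S1(=O)=O`). Compound 1 reads > 166 h and this is a limit of the assay, not a number. Compound 2 reads > 166 h and that too is only a limit. Compound 3 reads > 166 h and that is also a limit. All that places compound 2 is the limit of > 166 h in this assay, at which 3 of the 3 values shown sit, and it has no exact position.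

The change from compound 2 to compound 4 (`Cc1ccccc1CNC(=O)N1C(=O)c2ccccc2S1(=O)=O`) is methyl in place of fluoro on an aromatic carbon and amounts to methyl in place of fluoro on an aromatic carbon. Among the compounds with values here, the one measured step that bears on this, fluoro in place of bromo on an aromatic carbon, is a step that the two limits leave unreadable from compound 1 to compound 2 and so offers no size to carry over. No step beyond the usual scatter is expected in this assay and a step that the limit leaves unreadable from compound 2 to compound 4 is the estimated step. Compound 4 is expected near 200 h with an estimated range from 120 h to 400 h and may well read only as a limit again.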

Compound 4, half-life: > 166 h
Compound 4 was reported as a limit; the forecaster's own chance of this, stated with the estimate: 80%; the middle value does not contradict the limit.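

No step can be read between compound 4 and either compound 1 or compound 2, since each reading is a limit of the assay and not a number: the limit of > 166 h in this assay, at which 4 of the 4 values shown sit. The compounds shown leave open how long each actually lasts and whether bromo, fluoro and methyl differ at all.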